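A few compounds are considered here, and "the series" means these few. Any claim that something is new, unique, unknown or untested is made for them only; others in the source may bear on it.

Measured in a functional assay on MDA-MB-231 cells (Homo sapiens) for inhibition, read by CCK-8 assay, with a stated time of 48 h (a lower number here means a stronger inhibitor of growth, a higher number a weaker inhibitor of growth), as follows:
- Compound 1 `Cc1ccccc1Nc1nc(Nc2ccc(N3CCCCC3)cn2)ncc1Cl` gives > 100000 nM (a limit, not a number)
- Compound 2 `Cc1ccccc1Nc1nc(Nc2ccc(N3CCCCC3)cc2)ncc1Cl` gives 19900 nM
- Compound 3 `COc1ccc(CNc2nc(Nc3ccc(N4CCN(C)CC4)cn3)ncc2Cl)cc1` gives 14900 nM

Compound 3 (14900 nM) and compound 2 (19900 nM) lie within the scatter of each other, so the two stand level among the actual numbers. Compound 1 is known only as a limit (> 100000 nM).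

Compound 4 `CC(C)c1ccc(Nc2nc(Nc3ccc(N4CCN(C)CC4)cn3)ncc2Cl)cc1` has not yet been measured. It carries 4-isopropylphenyl in place of 4-methoxybenzyl on a nitrogen on an aromatic ring, so that the (4-methoxybenzyl)amino of compound 3 becomes (4-isopropylphenyl)amino (4-isopropylphenyl in place of 4-methoxybenzyl on a nitrogen on an aromatic ring).

For the measured compounds named here, no measured pair of compounds isolates this exchange, so the data give no direct size for it. The expectation in this assay is therefore modest, with no shift beyond the scatter and no firm direction. The estimated change is small (a 1.5-fold lower number from compound 3 to compound 4 (0.17 log units; within the scatter)) and remains an expectation only. With so few numbers to rest on, the expected range is kept wide. For compound 4 the estimated value is 10000 nM, with an expected range from 2500 nM to 40000 nM.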

Compound 4, concentration for 50% growth inhibition: 7020 nM
Compound 4: the middle estimate sits 1.4-fold (0.15 log units) above what was measured; the range from low to high includes it.
By their numbers in this assay, from the lowest: compound 4; then compounds 3 and 2 (each within the scatter of the next). At a limit, above all of these: compound 1.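

In this assay, for the compounds shown here, this position on the nitrogen turns out to be one where an exchange can move the number, and this is the first step that can be sized (a 2.1-fold lower number from compound 3 to compound 4 (0.33 log units; beyond the scatter)). The two groups hold the same count of heavy atoms, and each carries one six-membered aromatic ring of carbon only, so the shift appears without any change in the count of heavy atoms. What does differ is that the entering 4-isopropylphenyl is all carbon, whereas the leaving 4-methoxybenzyl holds an oxygen and a hydrogen-bond acceptor.

This single exchange alters both the link from the ring to the nitrogen and the group on the ring, so the compounds shown cannot say which of the two carries the step, and neither 4-methoxyphenyl nor 4-isopropylbenzyl on that nitrogen stands among them to separate the two. Going by these compounds alone, compound 1 is a limit of the assay and not a number, so it supplies no step for comparison: the limit of > 100000 nM in this assay, at which 1 of the 4 values shown sits.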